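This account rests on a few compounds, and the source may have more. Where it says the series, first, only, none or still open, it means among the compounds named here.

Measured in a functional assay on MCF7 cells (Homo sapiens) for antiproliferative activity, read by MTT assay, with a stated time of 48 h; a lower number here means a stronger inhibitor, a higher number a weaker inhibitor:
- compound 1 `CCn1c(C(=O)NCCCN(C)C)ccc1C(CC)(CC)c1ccc(OCCC(O)(CC)CC)c(C)c1`: 3350 nM
- compound 2 `CCn1c(C(=O)NCCN(C)C)ccc1C(CC)(CC)c1ccc(OCCC(O)(CC)CC)c(C)c1`: 430 nM
- compound 3 `C#CCCOC(=O)c1ccc(C(CC)(CC)c2ccc(OCCC(O)(CC)CC)c(C)c2)n1CC`: > 50000 nM (a limit of the assay, not a number)

On these data alone, compound 3 stands at the assay limit, so its true position is unknown and any step from it is open-ended.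

Compound 4 `CCC(C)C(NC(=O)c1ccc(C(CC)(CC)c2ccc(OCCC(O)(CC)CC)c(C)c2)n1CC)C(=O)OC` changes the group on the carbonyl carbon of compound 3: a group of 10 heavy atoms (7 carbon, 1 nitrogen, 2 oxygen; no ring) in place of a group of 5 heavy atoms (4 carbon, 1 oxygen; no ring), on a carbonyl carbon. The bearing steps are those that link the carbonyl substituents of the series. These are an at least 14-fold higher number from compound 1 to compound 3 (1.17 log units; beyond the scatter) and an at least 110-fold higher number from compound 2 to compound 3 (2.06 log units; beyond the scatter), both large and both toward weaker numbers on going to the (but-3-yn-1-yl)oxy group. Compound 4 shares a nitrogen on that carbonyl carbon with compounds 1 and 2, which argues for some recovery from the limit. However, its entering group has no dimethylamino group, and both active compounds carry one. The chain leading to that group also matters, as a 7.8-fold lower number from compound 1 to compound 2 (0.89 log units; beyond the scatter) is already beyond the scatter. Only part of the gap to compounds 1 and 2 is therefore expected to close, and a result at the limit remains quite possible.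

The expected change is a modest one toward a lower number in this assay, estimated as an at least 2.0-fold lower number from compound 3 to compound 4 (0.30 log units; that floor lies within the scatter). The estimate for compound 4 is 25000 nM, with an expected range of 7000 nM to 50000 nM.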

Compound 4, half-maximal inhibitory concentration: > 50000 nM
Compound 4: no number, only a limit; the forecaster's own chance of this, stated with the estimate: 45%; middle value at least 2.0-fold (0.30 log units) away from the limit.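

In this assay compound 4 gives > 50000 nM, a limit of the assay and not a number. An amide-type nitrogen on the carbonyl carbon therefore does not by itself bring a compound in this series to a readable number: compound 4 has that nitrogen but no dimethylamino group, and the gaps to the two compounds that do carry one are large, with an at least 110-fold higher number from compound 2 to compound 4 (2.06 log units; beyond the scatter) and an at least 14-fold higher number from compound 1 to compound 4 (1.17 log units; beyond the scatter). The step from compound 3 to compound 4 cannot be read, so neither the ester-to-amide change nor the entering group can be given a size or a direction, and the series now has two compounds at one ceiling: the limit of > 50000 nM in this assay, at which 2 of the 4 values shown sit.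

The compounds shown leave open whether the dimethylamino group is what separates compounds 1 and 2 from compound 4, or whether a primary amine on the same chain would also give a readable number. They also leave open how a carboxylic acid in place of the ester of the entering group in compound 4 would read, since a limit gives no baseline for that change.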